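Compound 3 to compound 4: benzyl to 4-methylbenzyl

The source may hold more compounds than are shown below. What is called first, only, known or untested is meant among the compounds shown, and "the series" means these compounds.

- compound 1 `CC(C)(C)c1cc(CCC(=O)NC2CCN(Cc3ccccc3)CC2)cc(C(C)(C)C)c1O` gives 80300 nM
- compound 2 `CC(C)(C)c1cc(CCC(=O)NCCC2CCN(Cc3ccccc3)CC2)cc(C(C)(C)C)c1O` gives 54500 nM
- compound 3 `CC(C)(C)c1cc(/C=C/C(=O)NCCC2CCN(Cc3ccccc3)CC2)cc(C(C)(C)C)c1O` gives 81700 nM

These three values come from a functional assay, read by spectrophotometry, with a stated time of 30 min (on this read-out higher numbers stand for weaker inhibition and lower numbers for stronger inhibition), and all lie within the scatter of one another. Compound 3 at 81700 nM therefore cannot be separated from compound 1 or compound 2 on these numbers. For the measured compounds named here, all three compounds sit in the same band of weak inhibition, and no measured pair differs in one place only.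

Compound 4 `Cc1ccc(CN2CCC(CCNC(=O)/C=C/c3cc(C(C)(C)C)c(O)c(C(C)(C)C)c3)CC2)cc1` is compound 3 with methyl in place of hydrogen on an aromatic carbon in the six-membered aromatic ring of carbon only, para to a large group. The change reads benzyl to 4-methylbenzyl. Going by the values given here, the measured compounds include no example of this change, so there is no direct precedent for its size or direction. The expectation in this assay is therefore anchored on compound 3 at 81700 nM and allows for no step beyond the scatter. The estimated step of a 1.2-fold lower number from compound 3 to compound 4 (0.07 log units; within the scatter) is expected to stay within the scatter, and neither direction is firmly favoured. The estimated value for compound 4 is 70000 nM (expected range 35000 nM to 140000 nM).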

Compound 4, half-maximal inhibitory concentration: 60400 nM
Estimate against measurement, compound 4: 1.2-fold (0.06 log units) above; the measured number falls inside the stated range.
By their numbers in this assay, from the lowest: compounds 2, 4, 1 and 3 (each within the scatter of the next).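

For the compounds shown here, compound 3 and compound 4 form the first pair that differs in one place only, and this gives the first direct reading of a change on the benzyl ring. In this assay the step from benzyl to 4-methylbenzyl is a 1.4-fold lower number from compound 3 to compound 4 (0.13 log units; within the scatter), so this single added carbon, on an aromatic carbon para to a large group, leaves compound 4 indistinguishable from compound 3 and in the same band of weak inhibition. No accompanying measurement bears on this result, and it offers no basis for assigning a cause.

One methyl at one place shows only that this particular replacement gives no step beyond the scatter, and it does not establish how the position responds in general. Going by these compounds, whether an amine, a carboxylic acid, a methoxy group, fluorine or a longer chain at the same aromatic carbon would give a step beyond the scatter in this assay remains open, as does the effect of any of these groups elsewhere on that ring.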